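Benzimidazolylmethyl anilines on MCF7 cells: halogen swap

The source may hold more compounds than are shown below. What is called first, only, known or untested is meant among the compounds shown, and "the series" means these compounds.

Measured so far:
compound 1, `COc1cc(N(Cc2nc3ccccc3[nH]2)S(=O)(=O)c2ccccc2Cl)cc(OC)c1OC`: 38100 nM
compound 2, `COc1cc(N(Cc2nc3ccccc3[nH]2)C(=O)c2ccc(F)cc2)cc(OC)c1OC`: 45200 nM

In a functional assay on MCF7 cells (Homo sapiens) for inhibition, read by MTT assay, with a stated time of 48 h (on this read-out lower numbers stand for stronger inhibition and higher numbers for weaker inhibition), compound 2 stands with the highest of the two numbers; its nearest neighbour is compound 1, and the step of a 1.2-fold higher number from compound 1 to compound 2 (0.07 log units; within the scatter) lies within the scatter, so the two are not ordered against each other.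

Compound 3, `COc1cc(N(Cc2nc3ccccc3[nH]2)C(=O)c2ccc(Br)cc2)cc(OC)c1OC`, has not yet been measured. It differs from compound 2 by bromo in place of fluoro on an aromatic carbon, a change on the aromatic carbon para to the carbonyl-bearing position of the benzoyl group. For the measured compounds named here, none of the measured steps is a halogen exchange; the only measured step, a 1.2-fold higher number from compound 1 to compound 2 (0.07 log units; within the scatter), replaces the whole acyl or sulfonyl group and showed no movement beyond the scatter. The series therefore gives no ground to expect a step in this assay beyond the scatter; the estimated step of a 1.3-fold lower number from compound 2 to compound 3 (0.11 log units; within the scatter) is small. Compound 3 is expected to give about 35000 nM in this assay, within 12000 nM to 100000 nM.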

Compound 3, half-maximal inhibitory concentration: > 50000 nM
Compound 3: only a limit was reported; the forecaster's own chance of this, stated with the estimate: 15%; middle value at least 1.4-fold (0.15 log units) from the limit.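

In this assay compound 3 carries a limit and not a number: the limit of > 50000 nM in this assay, at which 1 of the 3 values shown sits.

For the compounds shown here, the first halogen exchange, bromo in place of fluoro on an aromatic carbon para to a large group, can be read only as a floor, an at least 1.1-fold higher number from compound 2 to compound 3 (0.04 log units; that floor lies within the scatter), and it gives no sign of stronger inhibition at this position. The change from (2-chlorophenyl)sulfonyl to (4-bromophenyl)carbonyl is likewise only a floor, an at least 1.3-fold higher number from compound 1 to compound 3 (0.11 log units; that floor lies within the scatter), so bromo does not lift the carbonyl compound to a lower number than the sulfonyl compound.

As far as these compounds go, how far the true number for compound 3 lies past its limit stays open, and with it whether the bromo step exceeds the scatter. Also open, from the compounds shown here alone, is what an amine or a carboxylic acid would give in place of the halogen at this position.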